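The source may hold more compounds than are shown below. What is called first, only, known or untested is meant among the compounds shown, and "the series" means these compounds.

Measured compounds in a functional assay on A549 cells (Homo sapiens) for antiproliferative activity, read by MTT assay, with a stated time of 72 h; on this read-out higher numbers stand for weaker inhibition and lower numbers for stronger inhibition:
- compound 1 `COc1cc2ncnc(N3CCc4ccccc43)c2cc1NC(=O)/C=C/C(C)C`: compound 1 gives 6410 nM
- compound 2 `CCC/C=C/C(=O)Nc1cc2c(N3CCc4ccccc43)ncnc2cc1OC`: compound 2 gives 2920 nM

For the measured compounds named here, compound 2 holds the lowest of the two numbers; its only neighbour is compound 1, and the step of a 2.2-fold lower number from compound 1 to compound 2 (0.34 log units; beyond the scatter) sets the two apart beyond the scatter. The pair thus shows that the shape of the alkyl chain on the double-bonded chain carbon moves this assay by a modest amount.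

Compound 3 `COc1cc2ncnc(N3CCc4ccccc43)c2cc1NC(=O)/C=C/CN1CCCC1` is not yet measured. It differs from compound 2 by pyrrolidin-1-yl in place of ethyl on a saturated chain carbon bound to a double-bonded chain carbon. Going by the values given here, no measured step covers this kind of change: the one step in hand, from compound 1 to compound 2, swaps one alkyl chain for another of the same size, whereas here a ring with a nitrogen replaces ethyl on the saturated chain carbon. Among the compounds with values here, the prior step therefore gives no direction for this one, and the expectation rests on the small size of the only step seen. Compound 3 is expected to land close to compound 2, with a 1.5-fold lower number from compound 2 to compound 3 (0.16 log units; within the scatter) as the expected step, and an estimate of 2000 nM, in the range 500 nM to 8000 nM.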

Compound 3, half-maximal inhibitory concentration: 1210 nM
The estimate for compound 3 lay 1.7-fold (0.22 log units) above the measured number, within the range that was stated.
By their numbers in this assay, from the lowest: compound 3; then compound 2; then compound 1.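

In this assay, the saturated chain carbon bound to a double-bonded chain carbon accepts a ring with a nitrogen: pyrrolidin-1-yl in place of ethyl brings a 2.4-fold lower number from compound 2 to compound 3 (0.38 log units; beyond the scatter) and extends the fall in the number beyond what the change among alkyl chains had shown. Set against the branched chain, (pyrrolidin-1-yl)methyl in place of isopropyl brings a 5.3-fold lower number from compound 1 to compound 3 (0.72 log units; beyond the scatter), so compound 3 holds the lowest number of the three, with its steps to both others beyond the scatter. No measurement here bears on why the number falls with this change.

On these data alone, what stays open is whether the step follows the ring or the nitrogen: cyclopentyl on the same saturated chain carbon would separate the two, while dimethylamino, piperidin-1-yl or morpholin-4-yl there would show how far the step depends on the kind of amine. Also open, as far as these compounds go, is whether a longer chain between the double-bonded carbons and the pyrrolidin-1-yl ring would keep, deepen or lose the step.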